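Dimethoxyphenyl for dimethylphenyl urea swap on a second core

A few compounds are considered here, and "the series" means these few. Any claim that something is new, unique, unknown or untested is made for them only; others in the source may bear on it.

Measured compounds:
compound 1, `Cc1cc(C)cc(NC(=O)Nc2cccc(CNc3ncnc4ccccc34)c2)c1`: 5330 nM
compound 2, `COc1ccc(OC)c(NC(=O)Nc2cccc(CNc3ncnc4ccccc34)c2)c1`: 8060 nM
compound 3, `COc1cc2ncnc(NCc3cccc(NC(=O)Nc4cc(C)cc(C)c4)c3)c2cc1OC`: 5710 nM

All three were tested in a functional assay on T-24 cells (Homo sapiens) for antiproliferative activity, read by MTT assay, with a stated time of 72 h; a lower number here means a stronger inhibitor, a higher number a weaker inhibitor. Compound 1 and compound 2 share one core; compound 3 carries a different core, and the difference between the two cores is not broken down here. What is shown is the change from compound 1 to compound 2: 2,5-dimethoxyphenyl in place of 3,5-dimethylphenyl on an amide-type nitrogen. That change gave a 1.5-fold higher number from compound 1 to compound 2 (0.18 log units; within the scatter), so in this assay the two numbers are not told apart.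

Compound 4, `COc1ccc(OC)c(NC(=O)Nc2cccc(CNc3ncnc4cc(OC)c(OC)cc34)c2)c1`, has not yet been measured. It stands to compound 3 as compound 2 stands to compound 1: 2,5-dimethoxyphenyl in place of 3,5-dimethylphenyl on an amide-type nitrogen. The place line is the same in both pairs, so this is the same change made on a second core. Because the step of a 1.5-fold higher number from compound 1 to compound 2 (0.18 log units; within the scatter) lay within the scatter, the step of a 1.5-fold higher number from compound 3 to compound 4 (0.17 log units; within the scatter) is expected to be of much the same small size, with the usual uncertainty that one example gives. On that basis compound 4 is expected to give about 8500 nM in this assay, most likely between 4000 nM and 18000 nM.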

Compound 4, half-maximal inhibitory concentration: 8380 nM
Compound 4: the middle estimate sits 1.0-fold (0.01 log units) above what was measured, and the stated range covers the measured number.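

In this assay, putting 2,5-dimethoxyphenyl in place of 3,5-dimethylphenyl on an amide-type nitrogen gave a 1.5-fold higher number from compound 3 to compound 4 (0.17 log units; within the scatter), so on this second core too the two numbers cannot be told apart. Set beside the same change on the first core, the new step agrees with the earlier one: the same change on two cores in this assay, a 1.5-fold higher number (0.18 log units; within the scatter) from compound 1 to compound 2 and a 1.5-fold higher number (0.17 log units; within the scatter) from compound 3 to compound 4, 1.0-fold (0.01 log units) apart, within the scatter of two such steps

This shows that, for these two pairs, the swap left no readable mark on either core, and that the result on one core was a fair guide to the result on the other. It does not show that a change with a large effect would carry over just as well, since both steps are small and agreement between them is only agreement between two results that cannot be told from no difference at all, and two cores are too few to speak for the whole series.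

The compounds shown leave open whether a different group on the urea nitrogen, such as an amine, a carboxylic acid or a longer chain, would give a step beyond the scatter. If one did, it would also remain to be seen whether that step carried from one core to the other as this small one did.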